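The source may hold more compounds than are shown below. What is called first, only, known or untested is meant among the compounds shown, and "the series" means these compounds.

Of the compounds shown here, three have been measured in an assay on isolated protein for inhibition of endoplasmic reticulum aminopeptidase 1 (Homo sapiens), with stated times of 15 min and 20 min; on this read-out higher numbers stand for weaker inhibition and lower numbers for stronger inhibition. Compound 1 `O=C(NC1(C(=O)O)CCCCC1)c1cc(F)cc2cc(-c3ccc(Cl)cc3)oc12` gives 34 nM, compound 2 `O=C(NC1(C(=O)O)Cc2ccccc2C1)c1cc(F)cc2cc(-c3ccc(Cl)cc3)oc12` gives 115 nM, and compound 3 `CC(C)(NC(=O)c1cccc2cc(-c3ccc(Cl)cc3)oc12)C(=O)O` gives 1030 nM, the highest of the three numbers; its gap to compound 2 and its gap to compound 1 both lie beyond the scatter. Compound 4 `O=C(NC1(C(=O)O)CCCCC1)c1cccc2cc(-c3ccc(Cl)cc3)oc12` has not yet been measured. It differs from compound 3 in one place: 1-carboxycyclohexyl in place of 1-carboxy-1-methylethyl on an amide-type nitrogen. Compound 1 also carries the 1-carboxycyclohexyl group and gives 34 nM in this assay, so the step from compound 3 to compound 4 is expected to be a drop in the number that is clearly beyond the scatter, a 17-fold lower number from compound 3 to compound 4 (1.23 log units; beyond the scatter). Compound 4 is therefore estimated at 60 nM, with a likely range from 20 nM to 200 nM.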

Compound 4, half-maximal inhibitory concentration: 120 nM
Compound 4: the middle estimate sits 2.0-fold (0.30 log units) below what was measured; the range from low to high includes it.
By their numbers in this assay, from the lowest: compound 1; then compounds 2 and 4 (each within the scatter of the next); then compound 3.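

In this assay the 1-carboxycyclohexyl group in place of 1-carboxy-1-methylethyl on the amide-type nitrogen gives an 8.6-fold lower number from compound 3 to compound 4 (0.93 log units; beyond the scatter) with the rest of the molecule unchanged, so this one change alone produces a step beyond the scatter. Hydrogen in place of fluoro on the aromatic carbon gives a 3.5-fold higher number from compound 1 to compound 4 (0.55 log units; beyond the scatter) and also lies beyond the scatter, so the low number of compound 1 rests on the fluoro as well as on the 1-carboxycyclohexyl group. Nothing at hand explains either step. Still open, from the compounds shown here alone, is how a tetrazole in place of the carboxylic acid, or chloro in place of fluoro, would read, and whether the step from 1-carboxy-1-methylethyl to 1-carboxycyclohexyl keeps its size with fluoro present.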